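The source may hold more compounds than are shown below. What is called first, only, known or untested is meant among the compounds shown, and "the series" means these compounds.

In an ADME assay on microsomes from liver (Canis lupus familiaris) for metabolic stability (on this read-out lower numbers stand for a shorter-lived compound and higher numbers for a longer-lived compound), compound 1 `Nc1nc(NCCNc2ncc(-c3ncc[nH]3)c(-c3cc(F)ccc3Cl)n2)ccc1[N+](=O)[O-]` gives > 0.5 h, which is a limit and not a number. Compound 2 `Nc1nc(NCCNc2ncc(-c3ncc[nH]3)c(-c3ccc(F)cc3Cl)n2)ccc1[N+](=O)[O-]` gives > 0.5 h, which is also a limit. Compound 3 `Nc1nc(NCCNc2ncc(-c3ncc[nH]3)c(-c3ccc(F)cc3Br)n2)ccc1[N+](=O)[O-]` gives > 0.5 h, again a limit. Compound 3 therefore has no exact place in the series, which stands together at the limit of > 0.5 h in this assay, at which 3 of the 3 values shown sit.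

Compound 4 `Nc1nc(NCCNc2ncc(-c3ncc[nH]3)c(-c3ccc(Br)cc3Cl)n2)ccc1[N+](=O)[O-]` keeps the shared core and carries a 4-bromo-2-chlorophenyl in place of the 2-bromo-4-fluorophenyl of compound 3, on an aromatic carbon (4-bromo-2-chlorophenyl in place of 2-bromo-4-fluorophenyl on an aromatic carbon). Three measured changes touch the same aryl group. The nearest is a step that the two limits leave unreadable from compound 2 to compound 3, a swap of bromo for chloro. The others are a step that the two limits leave unreadable from compound 1 to compound 2 and a step that the two limits leave unreadable from compound 1 to compound 3. None of them has a size that can be read, so they offer no measured guide to how far this new change might move the half-life, or in which direction.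

The expectation therefore rests on the shared limit alone, and no direction is expected: the estimated change is a step that the limit leaves unreadable from compound 3 to compound 4. A further limit is the most likely report, given (the limit of > 0.5 h in this assay, at which 3 of the 3 values shown sit). For compound 4 the estimated half-life is 0.8 h, with an expected range from 0.5 h to 1.5 h.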

Compound 4, half-life: > 0.5 h
Compound 4: only a limit was reported; the forecaster's own chance of this, stated with the estimate: 80%; the middle value does not contradict the limit.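

Compound 4 gives a limit, just as compound 1, compound 2 and compound 3 do, so none of the steps that link compound 4 to them can be read in this assay: the limit of > 0.5 h in this assay, at which 4 of the 4 values shown sit.

The exact half-life of each of these compounds stays open, as does whether any of the changes on the phenyl group moves it at all.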